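The source may hold more compounds than are shown below. What is called first, only, known or untested is meant among the compounds shown, and "the series" means these compounds.

Compound 1, `CCOC(=O)CCCCCOc1cccc(CN(C(=O)c2ccccc2)C(C)C)c1`: in an ADME assay on HEK293 cells (Homo sapiens) for cytotoxicity, read by CellTiter-Glo and resazurin assay, with a stated time of 72 h (a lower number here means that less compound is needed, a higher number that more compound is needed for the effect), compound 1 gives > 26000 nM, which is a limit of the assay rather than a number.
Compound 2, `CCOC(=O)CCCCCOc1cccc(CN(C(=O)c2ccc(-c3cccc(N(C)C)c3)cc2)C(C)C)c1`: in this assay compound 2 gives > 26000 nM, again a limit.
Compound 3, `CCOC(=O)CCCCCOc1cccc(CN(C(=O)c2ccc(-c3cc(OC)cc(OC)c3)cc2)C(C)C)c1`: in this assay compound 3 gives > 26000 nM, also a limit.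

Compound 3 therefore stands nowhere in particular among the three: every value shown sits at the same limit, as the limit of > 26000 nM in this assay, at which 3 of the 3 values shown sit, records, and none of the three can be ordered against another. Compound 4, `CCOC(=O)CCCCCOc1cccc(CN(C(=O)c2ccc(-c3cccc(OC(F)(F)F)c3)cc2)C(C)C)c1`, is the next member of the series and has not yet been measured in this assay. It differs from compound 3 in one place: 3-(trifluoromethoxy)phenyl in place of 3,5-dimethoxyphenyl on an aromatic carbon.

Among the measured compounds shown here, two measured steps bear on this change, since both replace a hydrogen or an aryl group at the same aromatic carbon: a step that the two limits leave unreadable from compound 1 to compound 3 and a step that the two limits leave unreadable from compound 2 to compound 3. Neither has a readable size, because the limit of > 26000 nM in this assay, at which 3 of the 3 values shown sit, caps both ends of each. With every aryl variant so far returning only a limit, the expectation for compound 4 is no step beyond the scatter in this assay, with the value most likely reported as a limit once more.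

For compound 4 the estimated value in this assay is 30000 nM, with a range from 15000 nM to 80000 nM, which corresponds to an expected step that the limit leaves unreadable from compound 3 to compound 4.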

Compound 4, half-maximal effective concentration: > 26000 nM
Compound 4: a limit, no number; the forecaster's own chance of this, stated with the estimate: 85%; the middle value does not contradict the limit.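

Compound 4 gives > 26000 nM in this assay, which is a limit and not a number, so no step among compound 1, compound 2, compound 3 and compound 4 can be read, all sharing one ceiling: the limit of > 26000 nM in this assay, at which 4 of the 4 values shown sit.

The compounds shown leave open whether any aryl group on the shared core changes the effective concentration in this assay.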